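The source may report more compounds than this note shows. Statements on the series, on what has been measured and on what is new or still open speak of the compounds shown alone.

Compound 1 `Cc1cc(C(=O)O)ccc1-c1noc(-c2ccc(C3CCCCC3)cc2)n1` gives > 10000 nM in a functional assay on CHO cells with sphingosine 1-phosphate receptor 4 (Homo sapiens) as the target, read by GTPgammaS binding (on this read-out lower numbers stand for an effect already at smaller amounts and higher numbers for an effect only at larger amounts of compound), a limit of the assay.
Compound 2 `Cc1cc(CCC(=O)O)ccc1-c1noc(-c2ccc(OC(C)C)c(C(F)(F)F)c2)n1` gives > 10000 nM, again a limit.
Compound 3 `CCOc1ccc(-c2nc(-c3ccc(CCC(=O)O)cc3C)no2)cc1C(F)(F)F` gives > 10000 nM, also a limit.

Compound 2 stands at the limit of > 10000 nM in this assay, at which 3 of the 3 values shown sit. Compound 4 `Cc1cc(CCC(=O)O)ccc1-c1noc(-c2ccc(OC(C)C)c(Cl)c2)n1` differs from compound 2 by chloro in place of trifluoromethyl on an aromatic carbon. Within the data shown here, only one measured step speaks to a change on this ring: a step that the two limits leave unreadable from compound 2 to compound 3, whose size cannot be read because both ends are limits. So no size or direction of the step from compound 2 to compound 4 can be taken from the measured compounds, and the expected step in this assay is a number no higher from compound 2 to compound 4 (the limit leaves the size open). Compound 4 is therefore estimated at 10000 nM, with a range from 3000 nM to 30000 nM.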

Compound 4, half-maximal effective concentration: > 10000 nM
Compound 4: only a limit was reported; the forecaster's own chance of this, stated with the estimate: 85%; the middle value sits exactly at the limit.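

Among these compounds, compound 2 and compound 4 both end at a limit of the assay, and no step between them can be read. The compounds shown leave open how trifluoromethyl and chloro compare in this assay, and what actual number any of them would reach.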